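The compounds below may be only part of what the source reports. "The series", "measured", "known", "first", "only" and "open" are said of these compounds alone.

Compound 1, with the structure `COc1ccc(/C=C/C2CC(=O)C=CO2)cc1OC`, was tested in a functional assay on NCI-H460 cells (Homo sapiens) for inhibition, read by sulforhodamine B assay, with a stated time of 48 h (a lower number here means a stronger inhibitor of growth, a higher number a weaker inhibitor of growth), and gave 89.6 uM. Compound 2, `COc1cc(/C=C/C2CC(=O)C=CO2)cc(OC)c1OC`, carries one more group on the same core, the change being (methoxy in place of hydrogen on an aromatic carbon), and in this assay compound 2 gave 127 uM. The step of a 1.4-fold higher number from compound 1 to compound 2 (0.15 log units; within the scatter) is therefore a small one, and the two numbers cannot be ranked against each other.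

Compound 3, `COc1ccc(/C=C/c2cc(=O)cco2)cc1`, is built on a different core; the difference between the two cores is not broken down here. In this assay compound 3 gave 606 uM, the highest of the three numbers, standing beyond the scatter from both compound 2 and compound 1.

Compound 4, `COc1ccc(/C=C/c2cc(=O)cco2)cc1OC`, has not yet been measured. It differs from compound 3 by methoxy in place of hydrogen on an aromatic carbon. Among the measured compounds shown here, this is the same kind of change as the one from compound 1 to compound 2, though not the same: in compound 4 the new methoxy is ortho to a methoxy group and meta to a group of 9 heavy atoms, whereas in compound 2 it is in addition meta to a methoxy group. Because the step of a 1.4-fold higher number from compound 1 to compound 2 (0.15 log units; within the scatter) lay within the scatter, the step of a 1.2-fold higher number from compound 3 to compound 4 (0.06 log units; within the scatter) is expected to be similarly small. Compound 4 is thus estimated to give about 700 uM in this assay, with a likely range from 300 uM to 1500 uM.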

Compound 4, concentration for growth inhibition (reported as GI): 546 uM
The estimate for compound 4 lay 1.3-fold (0.11 log units) above the measured number, within the range that was stated.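

In this assay, among the compounds shown here, the methoxy that enters in place of hydrogen, here ortho to a methoxy group and meta to a group of 9 heavy atoms, gives a 1.1-fold lower number from compound 3 to compound 4 (0.05 log units; within the scatter), so on this second core the change again leaves no step that can be told from the scatter. Set side by side, the two steps do not differ by more than two such steps can be expected to differ: the same change on two cores in this assay, a 1.4-fold higher number (0.15 log units; within the scatter) from compound 1 to compound 2 and a 1.1-fold lower number (0.05 log units; within the scatter) from compound 3 to compound 4, 1.6-fold (0.20 log units) apart, within the scatter of two such steps. This shows that, across these two pairs, the change behaves alike in that neither step can be read as a real shift in growth inhibition, but it does not show that the change would stay this small on any other core, and it says nothing about why the cores themselves stand where they do.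

The compounds shown carry only methoxy groups on the aromatic ring, so it remains open whether a hydroxyl group, an amine or a carboxylic acid on that aromatic carbon would give a step beyond the scatter. Going by these compounds, it also remains open whether a longer chain in place of the methoxy, such as an ethoxy or butoxy group, would do so on either core.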